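The source may hold more compounds than are shown below. What is called first, only, known or untested is meant among the compounds shown, and "the series" means these compounds.

Compound 2 `CC(C)CC(=O)NC1CCCN1C(=O)/C=C/c1ccccc1` carries an (isobutylcarbonyl)amino group on its shared core. In a functional assay on Lu1 cells (Homo sapiens) for cytotoxicity (a lower number here means that less compound is needed, a higher number that more compound is needed for the effect), compound 2 gives > 5 ug/mL, which is a limit of the assay rather than a number. Compound 1 `C[S+]([O-])/C=C/C(=O)NC1CCCN1C(=O)/C=C/c1ccccc1` differs from it by a group on the same carbonyl carbon. In this assay compound 1 likewise gives only the limit > 5 ug/mL. Among the measured compounds shown here, the single measured step, a step that the two limits leave unreadable from compound 1 to compound 2, cannot be read because both of its ends sit at the limit (the limit of > 5 ug/mL in this assay, at which 2 of the 2 values shown sit). Compound 3 `COC1CCCN1C(=O)/C=C/c1ccccc1` is the compound still to be measured. The change is methoxy in place of (isobutylcarbonyl)amino on a saturated ring carbon. For the measured compounds named here, no measured step involves this saturated ring carbon, so the measured data give neither size nor direction for the coming step. With both measured compounds at the limit, compound 3 is expected to sit in the same region, estimated at 10 ug/mL within a range from 3 ug/mL to 40 ug/mL. The estimated step in this assay is a step that the limit leaves unreadable from compound 2 to compound 3.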

Compound 3, concentration for half-maximal effect: > 5 ug/mL
Compound 3: a limit, no number; the forecaster's own chance of this, stated with the estimate: 80%; the middle value is on the limit's open side.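

Compound 3 also gives only a limit of the assay rather than a number, so the step from compound 2 to compound 3 cannot be read: the limit of > 5 ug/mL in this assay, at which 3 of the 3 values shown sit.

The compounds shown leave open whether any of these groups on the shared core changes the concentration needed in this assay, and in which direction.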